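Capping the Diol: Compound 4 Expected Near Compound 3

The compounds below may be only part of what the source reports. "The series", "measured", "known", "first", "only" and "open" are said of these compounds alone.

In a functional assay on MCF7 cells (Homo sapiens) for cytotoxicity, read by MTT assay, with a stated time of 72 h (on this read-out lower numbers stand for stronger inhibition and higher numbers for weaker inhibition), compound 3 `O=C1c2c[n+]([O-])c3ccccc3c2C(=O)c2c1c1ccccc1n2Cc1cn(CC(O)CO)nn1` gives 1110 nM, the highest of the two numbers recorded. Compound 1 `O=C1c2c[n+]([O-])c3ccccc3c2C(=O)c2c1c1ccccc1n2Cc1cn([C@@H]2C[C@H](O)[C@@H](CO)O2)nn1` gives 110 nM. Compound 2 `O=C1c2c[n+]([O-])c3ccccc3c2C(=O)c2c1c1ccccc1n2Cc1cn(C[C@H](O)CO)nn1` gives only a limit, > 1000 nM. The steps of a 10-fold higher number from compound 1 to compound 3 (1.00 log units; beyond the scatter) and an at least 9.0-fold higher number from compound 1 to compound 2 (0.95 log units; beyond the scatter) both show that putting 2,3-dihydroxypropyl in place of the sugar-like ring weakens activity; the step that the limit leaves unreadable from compound 2 to compound 3 cannot be read because of the limit of > 1000 nM in this assay, at which 1 of the 3 values shown sits. Compound 4 `CC1(C)OC[C@H](Cn2cc(Cn3c4c(c5ccccc53)C(=O)c3c[n+]([O-])c5ccccc5c3C4=O)nn2)O1` differs from compound 3 by 2,2-dimethyl-1,3-dioxolan-4-yl in place of 1,2-dihydroxyethyl on a saturated chain carbon bound to an aromatic nitrogen. Going by the values given here, no measured step covers this change, so the direction is open and a wide range is warranted. Compound 4 is therefore expected to give about 1000 nM, between 300 nM and 4000 nM, in this assay. The implied step a 1.1-fold lower number from compound 3 to compound 4 (0.05 log units; within the scatter) is expected to stay within the scatter.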

Compound 4, half-maximal inhibitory concentration: 530 nM
Beside the measured number, compound 4's estimate is 1.9-fold (0.28 log units) above it; measured number inside the range.
By their numbers in this assay, from the lowest: compound 1; then compound 4; then compound 3.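

Putting 2,2-dimethyl-1,3-dioxolan-4-yl in place of 1,2-dihydroxyethyl on a saturated chain carbon bound to an aromatic nitrogen gives a 2.1-fold lower number from compound 3 to compound 4 (0.32 log units; beyond the scatter) in this assay, so this position accepts a group with no hydrogen-bond donors without losing activity. Where the starting value is a limit, the step reads only as a floor: an at least 1.8-fold lower number from compound 2 to compound 4 (0.27 log units; that floor lies within the scatter). The 4-hydroxy-5-(hydroxymethyl)oxolan-2-yl group still gives the lowest number: a 4.8-fold higher number from compound 1 to compound 4 (0.68 log units; beyond the scatter).

As far as these compounds go, it remains open whether the new ring or the capping of the hydroxyl groups accounts for the step. A 2,3-dimethoxypropyl chain in the same place would separate the two.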